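Reshaping the Side Chain of a Cytotoxic Quinoline-Free Scaffold

The source may hold more compounds than are shown below. What is called first, only, known or untested is meant among the compounds shown, and "the series" means these compounds.

Among the compounds with values here, compound 1 `COc1cc(NC(C)CCCNC(=O)NNC(=O)/C=C/c2cccc(C(F)(F)F)c2)c2ncccc2c1` is the only member of this small set for which a full number is available in an ADME assay on L6 cells (Rattus norvegicus) for cytotoxicity, read by resazurin assay, with a stated time of 70 h; a lower number here means a stronger inhibitor, a higher number a weaker inhibitor; compound 1 gives 10600 nM there. Compound 2 `COc1cc(NC(C)CCCNC(=O)NNC(=O)/C=C/c2cc(C(F)(F)F)cc(C(F)(F)F)c2)c2ncccc2c1` reaches only a limit of the assay, reported as > 170000 nM in this assay. Within the data shown here, because of the limit of > 170000 nM in this assay, at which 1 of the 2 values shown sits, the single measured step, trifluoromethyl in place of hydrogen on an aromatic carbon, is recorded as an at least 16-fold higher number from compound 1 to compound 2 (1.20 log units; beyond the scatter), a large loss of cytotoxic strength.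

Compound 3 `COc1cc(NC(C)CCCNC(=O)NNC(=O)Nc2ccc(C(F)(F)F)cc2)c2ncccc2c1` changes compound 1 in a different way: (4-(trifluoromethyl)phenyl)amino in place of 2-(3-(trifluoromethyl)phenyl)ethenyl on a carbonyl carbon. That measured step does not match this change, since here the trifluoromethyl count stays the same while the ethenyl bridge gives way to an amino link. Among the measured compounds shown here, the only guide is that the one measured change on this arm weakened activity sharply, so a move in the weakening direction is expected, but smaller. Compound 3 is therefore expected to give about 20000 nM in this assay. The plausible span for compound 3 is estimated as 7000 nM to 60000 nM. This corresponds to an expected step of a 1.9-fold higher number from compound 1 to compound 3 (0.28 log units; within the scatter).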

Compound 3, half-maximal inhibitory concentration: 14900 nM
Compound 3: middle estimate off by 1.3-fold (0.13 log units), on the high side; measured number inside the range.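

Replacing 2-(3-(trifluoromethyl)phenyl)ethenyl with (4-(trifluoromethyl)phenyl)amino on a carbonyl carbon gives a 1.4-fold higher number from compound 1 to compound 3 (0.15 log units; within the scatter) in this assay, so this position accepts a different link without a readable shift. A double bond outside the aromatic rings leaves and a hydrogen-bond donor enters, yet the two compounds read alike, so for this pair the ethenyl bridge is not required for a reading of this size. This comparison also rests on two full numbers, whereas the only large step in the set rests on a limit: the limit of > 170000 nM in this assay, at which 1 of the 3 values shown sits.

The swap alters the link and the placement of the trifluoromethyl group together, so the result cannot show whether each change alone would be as quiet or whether the two offset each other. As far as these compounds go, it also remains open whether a second trifluoromethyl group on the (4-(trifluoromethyl)phenyl)amino arm would bring the same large step, and what an amine or a carboxylic acid in place of trifluoromethyl on that ring would do.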